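Benzyl to (ethoxycarbonyl)methyl on the core of compound 3

This account rests on a few compounds, and the source may have more. Where it says the series, first, only, none or still open, it means among the compounds named here.

Working notes on the series in a functional assay on B16 cells (Mus musculus) for cytotoxicity, read by MTT assay, with a stated time of 48 h; a higher number here means a weaker inhibitor, a lower number a stronger inhibitor. Compound 1 `C#Cc1ccc(NC(=O)c2cn(Cc3ccccc3)nn2)cc1` is the benzyl member of the smaller core. In this assay compound 1 reaches only the limit > 100000 nM, a limit of the assay and not a number. Compound 2 `C#Cc1ccc(NC(=O)c2cn(CC(=O)OCC)nn2)cc1` carries the same change that is under study here, (ethoxycarbonyl in place of phenyl on a saturated chain carbon bound to an aromatic nitrogen). In this assay compound 2 likewise gives only the limit > 100000 nM, again a limit and not a number. The step between them, a step that the two limits leave unreadable from compound 1 to compound 2, therefore cannot be sized, because of the limit of > 100000 nM in this assay, at which 2 of the 3 values shown sit.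

Compound 3 `O=C(Nc1cccc(-c2cn(Cc3ccccc3)nn2)c1)c1cn(Cc2ccccc2)nn1` is built on a larger core; how the two cores differ is not broken down here. In this assay, within the data shown here, compound 3 gives 4500 nM, the single number in the set.

Compound 4 `CCOC(=O)Cn1cc(C(=O)Nc2cccc(-c3cn(Cc4ccccc4)nn3)c2)nn1` applies the same change to compound 3, (ethoxycarbonyl in place of phenyl on a saturated chain carbon bound to an aromatic nitrogen). Since the earlier instance is unreadable, the expected step of a 2.7-fold higher number from compound 3 to compound 4 (0.43 log units; beyond the scatter) rests only on compound 3 at 4500 nM and is uncertain. Compound 4 is estimated at 12000 nM, expected between 3000 nM and 60000 nM.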

Compound 4, half-maximal inhibitory concentration: 20400 nM
For compound 4 the middle estimate is 1.7-fold (0.23 log units) below the measured one; the range from low to high includes it.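

In this assay, ethoxycarbonyl in place of phenyl on a saturated chain carbon bound to an aromatic nitrogen gives a 4.5-fold higher number from compound 3 to compound 4 (0.66 log units; beyond the scatter), so on the core of compound 3 the change weakens the compound modestly, by more than the usual scatter. The same change on the core of compound 1 cannot be read, because neither compound of that pair gives a number: the limit of > 100000 nM in this assay, at which 2 of the 4 values shown sit. The series therefore holds one readable instance of this change, which shows its effect on a single core but does not show that the step carries over from one core to another, in either size or direction.

The compounds shown leave open whether the loss of activity belongs to ethoxycarbonyl in particular or would also appear with another group at that place, such as a carboxylic acid or an amine. Also open, as far as these compounds go, is how the core of compound 1 would respond to the change if its members gave numbers in this assay.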